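This account rests on a few compounds, and the source may have more. Where it says the series, first, only, none or still open, it means among the compounds named here.

Compound 1 `COc1ccc2cc(-c3ccccc3)c(O)nc2c1` and compound 2 `COc1ccc(-c2cc3c(OC)cc(OC)cc3n(C)c2=O)cc1` share a closely related core. In a functional assay on U-373MG ATCC cells for cytotoxicity against U373 MG (Homo sapiens), read by colorimetric assay and MTT assay (a lower number here means a stronger inhibitor, a higher number a weaker inhibitor), compound 1 gives 10000 nM. In this assay compound 2 gives 10000 nM, level with compound 1 at the digits shown, so the two lie within the usual scatter of each other. Compound 3 `COc1ccc(-c2cc3c(OC)cc(OC)cc3n(CCCC#N)c2=O)cc1` has not yet been tested; it differs from compound 2 by 2-cyanoethyl in place of hydrogen on a saturated chain carbon bound to an aromatic nitrogen. Among the compounds with values here, no measured pair shows what such a change does here. Compound 3 is expected to show a step of no change at the digits printed from compound 2 to compound 3 (within the scatter), none beyond the scatter. Compound 3 is therefore estimated at 10000 nM, within a range from 4000 nM to 25000 nM.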

Compound 3, half-maximal inhibitory concentration: 10000 nM
Compound 3: the middle estimate sits on the measured number at the digits printed; the range from low to high includes it.
By their numbers in this assay, from the lowest: compounds 1, 2 and 3 (each within the scatter of the next).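

In this assay, within the data shown here, the only measured pair for this position shows no change at the digits printed from compound 2 to compound 3 (within the scatter) with 2-cyanoethyl in place of hydrogen on a saturated chain carbon bound to an aromatic nitrogen. The position therefore accepts this nitrile-bearing chain with no step beyond the scatter, which compounds 1 and 2 alone could not show. No measured property offers an explanation for this result. The compounds shown leave open whether an amine, a carboxylic acid or a longer chain at this position would give a different reading.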